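This account rests on a few compounds, and the source may have more. Where it says the series, first, only, none or still open, it means among the compounds named here.

Three compounds have been measured in a functional assay on DU-145 cells (Homo sapiens) for cytotoxicity, read by ELISA, with a stated time of 4 days (a higher number here means a weaker inhibitor, a lower number a stronger inhibitor), so far:
- compound 1 `Cc1ccsc1-c1cc(-c2ccco2)cc(-c2ccc(Cl)cc2)n1` with 26700 nM
- compound 2 `Clc1ccc(-c2cc(-c3ccoc3)cc(-c3ccco3)n2)s1` with 17200 nM
- compound 3 `Cc1cccc(-c2cc(-c3ccoc3)cc(-c3ccc(Cl)s3)n2)c1` with 20300 nM

These three values lie within the usual scatter of one another, so they cannot be ranked. Compound 3, at 20300 nM in this assay, sits within that scatter of both compound 2 and compound 1, and it is the starting point here.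

The next compound, compound 4 `Clc1cccc(-c2cc(-c3ccoc3)cc(-c3ccc(Cl)s3)n2)c1`, has not yet been measured. It differs from compound 3 in one place, with chloro in place of methyl on an aromatic carbon, which turns 3-methylphenyl into 3-chlorophenyl.

Among the measured compounds shown here, no measured pair compares chloro with methyl directly, so the evidence is thin. For the measured compounds named here, the one measured step that bears on this group is a 1.2-fold higher number from compound 2 to compound 3 (0.07 log units; within the scatter) and it came from 3-methylphenyl in place of furan-2-yl on an aromatic carbon. Even that larger exchange stayed within the scatter, so a swap of one small group is not expected to do more.

The expected step is a 1.0-fold lower number from compound 3 to compound 4 (0.01 log units; within the scatter) and this means no change beyond the scatter is anticipated. For compound 4 the estimated value is 20000 nM with an expected range from 9000 nM to 40000 nM in this assay once it is measured.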

Compound 4, half-maximal inhibitory concentration: 23000 nM
The estimate for compound 4 lay 1.2-fold (0.06 log units) below the measured number, and the stated range covers the measured number.
By their numbers in this assay, from the lowest: compounds 2, 3, 4 and 1 (each within the scatter of the next).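

In this assay, among the compounds shown here, chloro in place of methyl on an aromatic carbon, meta to a large group, gives a 1.1-fold higher number from compound 3 to compound 4 (0.05 log units; within the scatter), and this is the first direct comparison of these two small groups at this place. Replacing furan-2-yl with 3-chlorophenyl gives a 1.3-fold higher number from compound 2 to compound 4 (0.13 log units; within the scatter), so furan-2-yl, 3-methylphenyl and 3-chlorophenyl cannot be told apart at this place in this assay, whether the exchange swaps one small group or a whole ring. No measurement available here offers an explanation for this flat result.

The compounds shown leave open whether a group of a different kind at this place, such as an amine, a carboxylic acid or a longer chain, would move the number beyond the scatter. From the compounds shown here alone, it also remains open whether a single change elsewhere on the shared core would have a larger effect in this assay than the exchanges compared so far.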